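A Hydroxy Added to the 2-(furan-3-yl)ethyl Chain

The compounds below may be only part of what the source reports. "The series", "measured", "known", "first", "only" and "open" are said of these compounds alone.

In a functional assay on MDA-MB-231 cells (Homo sapiens) for cytotoxicity, read by MTT assay, with a stated time of 48 h (a lower number here means a stronger inhibitor, a higher number a weaker inhibitor), compound 1 (`C=C1CC[C@@H]2[C@](C)(CO)[C@H](O)CC[C@@]2(C)[C@@H]1CCc1ccoc1`) gives > 100000 nM, which is a limit of the assay and not a number. Compound 2 (`C=C1CC[C@@H]2[C@](C)(COC(=O)c3ccc([N+](=O)[O-])cc3)[C@H](O)CC[C@@]2(C)[C@@H]1CCc1ccoc1`) gives 37500 nM, a measured value. Compound 3 (`C=C1CC[C@@H]2[C@](C)(CO)[C@H](O)CC[C@@]2(C)[C@@H]1CC(O)c1ccoc1`) changes compound 1 elsewhere: hydroxy in place of hydrogen on a saturated chain carbon bound to an aromatic carbon and a saturated chain carbon. Going by the values given here, only one measured step is available, an at least 2.6-fold lower number from compound 1 to compound 2 (0.42 log units; beyond the scatter), and it places (4-nitrophenyl)carbonyl on an oxygen on a saturated carbon, so it is a weak guide to this different change. No clear gain is therefore expected, and compound 3 may well be reported only as a limit too. The estimated change is a step that the limit leaves unreadable from compound 1 to compound 3, with no expected step beyond the scatter. For compound 3 the estimate is 120000 nM, with an expected range from 50000 nM to 300000 nM.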

Compound 3, half-maximal inhibitory concentration: > 100000 nM
Compound 3 was reported as a limit (the forecaster's own chance of this, stated with the estimate: 75%); the middle value is on the limit's open side.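

Compound 1 and compound 3 are both reported only as limits, not as numbers, so no step between them can be read: the limit of > 100000 nM in this assay, at which 2 of the 3 values shown sit.

As far as these compounds go, whether hydroxy on the 2-(furan-3-yl)ethyl chain changes the cytotoxicity at all remains open.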